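Thiazole Carbonyl in Place of Fluorocyclobutyl Carbonyl

The compounds below may be only part of what the source reports. "The series", "measured", "known", "first", "only" and "open" are said of these compounds alone.

compound 1, `CN1CCc2nc(C#Cc3cccc(F)c3)sc2C1`: > 10000 nM
compound 2, `O=C(C1CC(F)C1)N1CCc2nc(C#Cc3ccccc3)sc2C1`: 85 nM

In an assay on HEK293 cells for positive allosteric modulation of metabotropic glutamate receptor 5 (Homo sapiens), read by FLIPR, with a stated time of 1 h (a higher number here means that more compound is needed for the effect, a lower number that less compound is needed), compound 1 reaches only the limit of the assay, > 10000 nM; this is the limit described by the limit of > 10000 nM in this assay, at which 1 of the 2 values shown sits. Among the compounds with values here, compound 2 is the one compound here with a number, giving 85 nM in this assay. Compound 3, `Cc1nc(C(=O)N2CCc3nc(C#Cc4ccccc4)sc3C2)cs1`, keeps the core of compound 2 and changes the group on the carbonyl carbon.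

2-methyl-1,3-thiazol-4-yl in place of 3-fluorocyclobutyl on a carbonyl carbon

Within the data shown here, no measured step stands between compounds of this set, so there is nothing to calibrate the size of this change. The step of a 1.2-fold lower number from compound 2 to compound 3 (0.08 log units; within the scatter) is expected to stay within the usual scatter. Compound 3 is therefore estimated at 70 nM, between 20 nM and 300 nM.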

Compound 3, half-maximal effective concentration: 220 nM
Estimate against measurement, compound 3: 3.1-fold (0.50 log units) below; measured number inside the range.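

Within the data shown here, putting 2-methyl-1,3-thiazol-4-yl in place of 3-fluorocyclobutyl on the carbonyl carbon gives a 2.6-fold higher number from compound 2 to compound 3 (0.41 log units; beyond the scatter) in this assay and is the first measured step at this position. It shows that the position accepts a five-membered aromatic ring at a modest cost, since compound 3 still gives a number and not a limit. Nothing measured here accounts for this step.

From the compounds shown here alone, whether the methyl on the thiazole matters remains open. So does how a plain phenyl, a pyridine or an unfluorinated cyclobutyl on the same carbonyl carbon would compare.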